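Sulfonyl substituent exchange at a shared pyridopyrimidinone core

The source may hold more compounds than are shown below. What is called first, only, known or untested is meant among the compounds shown, and "the series" means these compounds.

Three compounds have been measured in a functional assay on K562 cells (Homo sapiens) for inhibition, read by trypan blue exclusion, with a stated time of 72 h; a lower number here means a stronger inhibitor, a higher number a weaker inhibitor:

Compound 1, `Cn1c(=O)c(S(=O)(=O)Cc2ccc(F)cc2F)cc2cnc(Nc3ccc4[nH]ccc4c3)nc21`, gives 1000 nM.
Compound 2, `Cc1ccc(S(=O)(=O)c2cc3cnc(Nc4ccc5cc[nH]c5c4)nc3n(C)c2=O)cc1`, gives 15000 nM.
Compound 3, `Cn1c(=O)c(S(=O)(=O)c2ccc(F)cc2)cc2cnc(Nc3cnc4[nH]ccc4c3)nc21`, gives 750 nM.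

Among these three numbers compound 1 stands second highest. Its nearest neighbour is compound 3, whose value lies within the usual scatter of compound 1, so no order between the two can be stated. Compound 2 lies furthest away, with a number beyond the scatter and well above that of compound 1.

The unmeasured compound 4, `Cn1c(=O)c(S(=O)(=O)c2ccc(F)cc2N)cc2cnc(Nc3ccc4[nH]ccc4c3)nc21`, differs from compound 1 in one place: 2-amino-4-fluorophenyl in place of 2,4-difluorobenzyl on a sulfonyl sulfur. In both compound 3 and compound 4 the sulfonyl sulfur carries an aromatic ring directly, and compound 3 sits close to compound 1 in this assay, so the step from compound 1 to compound 4 is expected to be small, with no clear direction beyond the scatter. The step of a 1.3-fold lower number from compound 1 to compound 4 (0.10 log units; within the scatter) is thus expected to stay within the scatter. Compound 4 is expected to give about 800 nM, with a range from 250 nM to 2500 nM.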

Compound 4, half-maximal inhibitory concentration: 2000 nM
For compound 4 the middle estimate is 2.5-fold (0.40 log units) below the measured one, within the range that was stated.
By their numbers in this assay, from the lowest: compounds 3, 1 and 4 (each within the scatter of the next, the first and the last beyond it); then compound 2.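

For the compounds shown here, the exchange of 2,4-difluorobenzyl for 2-amino-4-fluorophenyl on a sulfonyl sulfur gives the first comparison in which only this substituent differs, and in this assay it amounts to a 2.0-fold higher number from compound 1 to compound 4 (0.30 log units; within the scatter). No order can therefore be stated between the two compounds, even though the entering group attaches its aromatic ring directly to the sulfur and brings a hydrogen-bond donor that the leaving group lacks. Nothing available explains the result or links it to any property of either group.

The compounds shown leave open whether this insensitivity extends to substituents of other kinds on the sulfonyl sulfur, such as a carboxylic acid, a morpholine or a longer alkyl chain. They also do not separate the contribution of the amino group from that of the rest of the 2-amino-4-fluorophenyl group.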